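Series notes: 3-aminophenyl in place of 4-(methoxycarbonyl)phenyl

The source may report more compounds than this note shows. Statements on the series, on what has been measured and on what is new or still open speak of the compounds shown alone.

In a functional assay on SK-OV-3 cells (Homo sapiens) for inhibition, read by CCK-8 assay, with a stated time of 70 h (a higher number here means a weaker inhibitor, a lower number a stronger inhibitor), compound 1 (`COc1ccc(COc2ccc(OCCOCCNC3CCCC3)cc2)cc1`) gives 15700 nM and compound 2 (`COC(=O)c1ccc(COc2ccc(OCCOCCNC3CCCC3)cc2)cc1`) gives 6990 nM. Compound 2 therefore holds the lower of the two numbers and is the stronger inhibitor of the pair. The next structure, compound 3 (`Nc1cccc(COc2ccc(OCCOCCNC3CCCC3)cc2)c1`), is unmeasured and differs from compound 2 as follows: 3-aminophenyl in place of 4-(methoxycarbonyl)phenyl on a saturated chain carbon bound to an oxygen on an aromatic ring. That is 3-aminophenyl in place of 4-(methoxycarbonyl)phenyl on a saturated chain carbon bound to an oxygen on an aromatic ring. Among the compounds with values here, only one measured step bears on this change: a 2.2-fold lower number from compound 1 to compound 2 (0.35 log units; beyond the scatter), with methoxycarbonyl in place of methoxy on an aromatic carbon. Within the data shown here, no measured compound carries a 3-aminophenyl group, so that step offers only a rough guide to size. A small move toward a higher number in this assay is expected, namely a 1.7-fold higher number from compound 2 to compound 3 (0.23 log units; within the scatter). The estimate for compound 3 is 12000 nM, with an expected range of 4500 nM to 28000 nM.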

Compound 3, half-maximal inhibitory concentration: 10800 nM
For compound 3 the middle estimate is 1.1-fold (0.05 log units) above the measured one; the measured number falls inside the stated range.
By their numbers in this assay, from the lowest: compounds 2, 3 and 1 (each within the scatter of the next, the first and the last beyond it).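

In this assay, placing 3-aminophenyl on a saturated chain carbon bound to an oxygen on an aromatic ring gives a 1.5-fold higher number from compound 2 to compound 3 (0.19 log units; within the scatter) and a 1.5-fold lower number from compound 1 to compound 3 (0.16 log units; within the scatter), so this group cannot be separated from either 4-(methoxycarbonyl)phenyl or 4-methoxyphenyl. Within the data shown here, the earlier pair compared only two groups bearing oxygen, whereas compound 3 shows that a group with a hydrogen-bond donor and nitrogen in place of oxygen also gives a number that sits within the scatter of both, leaving the gap between compound 1 and compound 2 as the only step beyond it. No supporting evidence bears on these numbers.

The compounds shown leave open how 4-aminophenyl or 3-methoxyphenyl would compare, so the identity of the substituent and its ring position remain unseparated. Also open, as far as these compounds go, is whether a carboxylic acid or an unsubstituted phenyl would stay within this narrow spread.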